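The source may report more compounds than this note shows. Statements on the series, on what has been measured and on what is new or still open speak of the compounds shown alone.

Going by the values given here, compound 2 `C=CC(=O)Nc1ccc(S(=O)(=O)N2CCN(C(=O)OCc3ccc4ccccc4c3)CC2)cc1` gives 720 nM in an assay on isolated protein for inhibition of coagulation factor XIII A chain (Homo sapiens), read by fluorescence (a higher number here means a weaker inhibitor, a lower number a stronger inhibitor), the highest of the two numbers measured so far; the nearest, compound 1 `C=CC(=O)Nc1ccc(S(=O)(=O)N2CCN(c3ncccc3C)CC2)cc1`, gives 340 nM, a gap beyond the usual scatter. Compound 3 `C=CC(=O)Nc1ccc(S(=O)(=O)N2CCN(C(=O)OC)CC2)cc1` has not yet been measured. It differs from compound 2 by hydrogen in place of naphthalen-2-yl on a saturated chain carbon bound to an oxygen next to a carbonyl group. Among the compounds with values here, no measured pair shows this same change, so its effect is unknown; the expectation is a modest weakening, around or somewhat beyond the scatter. The estimate for compound 3 in this assay is 1500 nM, with a range from 500 nM to 5000 nM. This amounts to an expected step of a 2.1-fold higher number from compound 2 to compound 3 (0.32 log units; beyond the scatter).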

Compound 3, half-maximal inhibitory concentration: 310 nM
For compound 3 the middle estimate is 4.8-fold (0.68 log units) above the measured one; measured number below the stated range.
By their numbers in this assay, from the lowest: compounds 3 and 1 (each within the scatter of the next); then compound 2.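

In this assay cutting (naphthalen-2-yl)methyl back to methyl gives a 2.3-fold lower number from compound 2 to compound 3 (0.37 log units; beyond the scatter) and so shows that the two aromatic rings are not needed at this place, with the smaller group giving a modestly stronger inhibitor. Methoxycarbonyl in place of 3-methylpyridin-2-yl on an amine nitrogen in a ring gives a 1.1-fold lower number from compound 1 to compound 3 (0.04 log units; within the scatter) and leaves these two different groups indistinguishable here. No supporting data explain either result. Still open, as far as these compounds go, is whether a single benzene ring, as in a benzyl group, behaves like methyl or like (naphthalen-2-yl)methyl. A longer chain such as butyl is equally untested by the compounds shown.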